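This account rests on a few compounds, and the source may have more. Where it says the series, first, only, none or still open, it means among the compounds named here.

Of the compounds shown here, two have been measured in a functional assay on PC-12 cells (Rattus norvegicus) for cytotoxicity, read by MTT assay, with stated times of 2 h and 24 h, tested at 10 uM; a lower number here means a weaker effect, a higher number a stronger effect of the compound at the concentration tested. Compound 1, whose structure is `Oc1cc(C(F)(F)F)ccc1-c1nc(-c2ccccc2O)n(-c2cccc(Cl)c2)n1`, gives 100% there. Compound 2, whose structure is `Oc1cc(C(F)(F)F)ccc1-c1nc(-c2ccccc2O)n(-c2ccc(Cl)cc2Cl)n1`, gives 95.2% in this assay. Among the measured compounds shown here, the only step between measured compounds, a number 4.8 percentage points lower from compound 1 to compound 2 (within the scatter), replaces one ring on the same aromatic nitrogen with another and leaves the read-out within the scatter, so compound 2 stands together with compound 1, the only other measured compound, at a near-complete effect.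

Compound 3, whose structure is `Cc1cc(C)cc(-n2nc(-c3ccc(C(F)(F)F)cc3O)nc2-c2ccccc2O)c1`, has not yet been measured. It differs from compound 2 in one place: 3,5-dimethylphenyl in place of 2,4-dichlorophenyl on an aromatic nitrogen. This is again an exchange of the ring on the aromatic nitrogen, the same kind of change as the step from compound 1 to compound 2. That step stayed within the scatter, so no step beyond the scatter is expected here either, in either direction.

The estimate for compound 3 in this assay is therefore 93%, with a range from 75% to 100%, which means an expected step of a number 2.2 percentage points lower from compound 2 to compound 3 (within the scatter).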

Compound 3, a percentage reported as activity, at one concentration (the size of the read-out at that concentration, not a potency): 105%
Estimate against measurement, compound 3: 12 percentage points below; measured number above the stated range.
By their numbers in this assay, from the lowest: compounds 2, 1 and 3 (each within the scatter of the next).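

Putting 3,5-dimethylphenyl in place of 2,4-dichlorophenyl on the aromatic nitrogen gives a number 9.8 percentage points higher from compound 2 to compound 3 (within the scatter) in this assay and putting it in place of 3-chlorophenyl gives a number 5 percentage points higher from compound 1 to compound 3 (within the scatter) in this assay as well. The earlier step only exchanged one chlorine-bearing ring for another, whereas compound 3 shows that among these three compounds a ring with no chlorine at all, carrying two methyl groups instead, stands at the same near-complete effect as the chlorinated rings. Nothing available here explains why the read-out holds across these rings.

On these data alone, all three compounds carry only chlorine or methyl on this phenyl ring, so it stays open what an amine or a carboxylic acid on the ring, or a longer chain in place of the ring, would do to the read-out. Because all three numbers stand together at a single tested concentration, they also leave open whether any change at this position can lower the effect, and whether any of these compounds would show a stronger or weaker effect than the others at another concentration.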